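Chain-shortened iodoacetamide nucleotide analogue: expected inhibition

The compounds below may be only part of what the source reports. "The series", "measured", "known", "first", "only" and "open" are said of these compounds alone.

In an assay on isolated protein for inhibition of hexokinase-2 (Rattus norvegicus), with a stated time of 6 h, tested at 10 mM (on this read-out higher numbers stand for more inhibition at the one concentration tested (going by the name of the read-out) and lower numbers for less inhibition), compound 1 `O=C(CI)NCCCCCC(=O)NCCCCCCNc1ncnc2c1ncn2[C@@H]1O[C@H](COP(=O)(O)OP(=O)(O)OP(=O)(O)O)[C@@H](O)[C@H]1O` gives 0%. In this assay compound 2 `Nc1ncnc2c1nc(NCCCCCCCCNC(=O)CI)n2[C@@H]1O[C@H](COP(=O)(O)OP(=O)(O)OP(=O)(O)O)[C@@H](O)[C@H]1O` gives 0%; the two values sit level within the scatter, so neither is ranked against the other. Within the data shown here, no step between measured compounds is available for this series. Compound 3 `O=C(CI)NCCCCC(=O)NCCCCCCNc1ncnc2c1ncn2[C@@H]1O[C@H](COP(=O)(O)OP(=O)(O)OP(=O)(O)O)[C@@H](O)[C@H]1O` differs from compound 1 in one place: ((iodomethyl)carbonyl)amino in place of (((iodomethyl)carbonyl)amino)methyl on a saturated chain carbon, four bonds along the chain from a carbonyl carbon. With both measured values at the floor, the step from compound 1 to compound 3 is expected to be none beyond the scatter, no change at the digits printed from compound 1 to compound 3 (within the scatter). For compound 3 the expected value is 0%, with a range from -5% to 10%.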

Compound 3, a percentage reported as inhibition, at one concentration (the size of the read-out at that concentration, not a potency): 0%
Beside the measured number, compound 3's estimate shows no gap at the digits printed; low and high end bracket the measured number.
By their numbers in this assay, from the lowest: compounds 1, 2 and 3 (each within the scatter of the next).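

In this assay, the shorter tether of compound 3 gives no change at the digits printed from compound 1 to compound 3 (within the scatter): ((iodomethyl)carbonyl)amino in place of (((iodomethyl)carbonyl)amino)methyl leaves the read-out at the floor. At this position, the change therefore gives no measurable gain in inhibition, though a floor reading cannot show whether the change has any effect. Nothing available explains the result.

As far as these compounds go, whether a longer chain, or an acrylamide in place of the iodoacetamide end, would produce measurable inhibition remains open. From the compounds shown here alone, it also remains open whether any chain length matters.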